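A few compounds are considered here, and "the series" means these few. Any claim that something is new, unique, unknown or untested is made for them only; others in the source may bear on it.

In an ADME assay on microsomes from liver (Homo sapiens) for metabolic stability, read by LC-MS, using NADPH, with a stated time of 10 min, tested at 10 uM (on this read-out lower numbers stand for a shorter-lived compound and higher numbers for a longer-lived compound), compound 3 `Nc1ncnc2c1c(Oc1cc(Cl)ccn1)nn2C1CCC1` gives 0.333 h and stands level with compound 1 `Nc1ncnc2c1c(Oc1cc(C(F)(F)F)ccn1)nn2C1CCCC1` at 0.333 h while compound 2 `CO[C@H]1CC[C@@H](n2nc(Oc3cc(C(F)(F)F)ccn3)c3c(N)ncnc32)CC1` gives 0.317 h within the scatter of both. Compound 4 `Nc1ncnc2c1c(Oc1cc(C(F)(F)F)ccn1)nn2C1CCC1` keeps the nitrogen substituent of compound 3 and carries trifluoromethyl in place of chloro on an aromatic carbon. Within the data shown here, no measured step isolates this exchange. Among the measured compounds shown here, the one measured step, a 1.1-fold lower number from compound 1 to compound 2 (0.02 log units; within the scatter) with 4-methoxycyclohexyl in place of cyclopentyl on an aromatic nitrogen, lies within the scatter but concerns another place in the molecule. For the measured compounds named here, the only indirect evidence is that compound 1 and compound 2 both carry trifluoromethyl, and their values sit level or within the scatter of the value for compound 3, which carries chloro. In this assay no shift beyond the scatter and no particular direction is therefore expected, and the estimated step of a 1.0-fold lower number from compound 3 to compound 4 (0.00 log units; within the scatter) stays small. Compound 4 is estimated at 0.33 h (expected range 0.2 h to 0.5 h).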

Compound 4, half-life: 1.02 h
Compound 4: the middle estimate sits 3.1-fold (0.49 log units) below what was measured; the whole stated range lies below it.
By their numbers in this assay, from the lowest: compounds 2, 1 and 3 (each within the scatter of the next); then compound 4.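

In this assay, trifluoromethyl in place of chloro on an aromatic carbon, opposite the ring nitrogen, gives a 3.1-fold higher number from compound 3 to compound 4 (0.49 log units; beyond the scatter) with cyclobutyl held on the nitrogen, so this position can move the half-life. The nitrogen substituent also counts with trifluoromethyl held: cyclobutyl in place of cyclopentyl gives a 3.1-fold higher number from compound 1 to compound 4 (0.49 log units; beyond the scatter), and cyclobutyl in place of 4-methoxycyclohexyl gives a 3.2-fold higher number from compound 2 to compound 4 (0.51 log units; beyond the scatter), although the exchange between those two larger groups had stayed within the scatter. Among these compounds, the longer half-life appears only in compound 4, the one compound here that joins trifluoromethyl and cyclobutyl.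

Nothing in the data shown explains this rise. Going by these compounds, whether it would also appear with a nitrile or a methyl group in place of trifluoromethyl, or with an azetidine on the nitrogen, remains open.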